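A Methyl Added to the Propyl Chain

The compounds below may be only part of what the source reports. "The series", "measured", "known", "first", "only" and "open" are said of these compounds alone.

Of the compounds shown here, two with a shared core have been measured in an ADME assay on MT4 cells (Homo sapiens) for activation, read by MTT assay; on this read-out lower numbers stand for higher toxicity in this test and higher numbers for lower toxicity in this test. Compound 1 `CC(C)Sc1nc(Cc2c(F)cccc2Cl)cc(=O)[nH]1` gives > 80000 nM, which is a limit of the assay and not a number. Compound 2 `CCCSc1nc(Cc2c(F)cccc2Cl)cc(=O)[nH]1` gives > 80000 nM, which is also a limit. Compound 2 therefore has no numerical position and stands at the limit of > 80000 nM in this assay, at which 2 of the 2 values shown sit.

Compound 3 `CCC(C)Sc1nc(Cc2c(F)cccc2Cl)cc(=O)[nH]1` differs from compound 2 by one change: methyl in place of hydrogen on a saturated chain carbon bound to a saturated chain carbon and a sulfur. This turns propyl to sec-butyl on the sulfur. Among the compounds with values here, the only measured step that bears on this change is a step that the two limits leave unreadable from compound 1 to compound 2, with propyl in place of isopropyl on a sulfur. That step offers no size to carry forward. Within the data shown here, with only that unreadable step as a guide, no step beyond the scatter is expected in this assay, and another limit is the likeliest report. The expected step is a number no higher from compound 2 to compound 3 (the limit leaves the size open). For compound 3 the estimated value is 80000 nM, with an expected range from 40000 nM to 120000 nM.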

Compound 3, half-maximal cytotoxic concentration: > 76000 nM
Compound 3: a limit, no number (the forecaster's own chance of this, stated with the estimate: 75%); the middle value is on the limit's open side.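

In this assay compound 3 gives > 76000 nM, which is a limit and not a number. As compound 1 and compound 2 also stand at limits, none of the steps among the three compounds can be read. The compounds shown leave open where any of the three would give a number, and whether the added methyl changes the read-out at all.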